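The source may hold more compounds than are shown below. What is called first, only, known or untested is meant among the compounds shown, and "the series" means these compounds.

In an ADME assay on PBMC cells (Homo sapiens) for cytotoxicity, read by MTT assay, with a stated time of 72 h, in the presence of a further agent that is not named here (a lower number here means a stronger inhibitor, a higher number a weaker inhibitor), compound 1 (`COc1ccc(Nc2ccc3ccccc3n2)cc1`) gives 70000 nM, compound 2 (`COc1ccc(Nc2cc(-c3cccc(C(F)(F)F)c3)ccn2)cc1`) gives 105000 nM, and compound 3 (`CCc1ccc(Nc2nc3ccccc3cc2-c2ccccc2)cc1`) gives 66000 nM. These three values lie within the usual scatter of one another, so compound 3 stands level with compound 1 and compound 2, and no ranking can be drawn from them.

Next in the series is compound 4 (`COc1cccc(Nc2nc3ccccc3cc2-c2ccccc2)c1`). It keeps the core of compound 3 and carries 3-methoxyphenyl in place of 4-ethylphenyl on a nitrogen on an aromatic ring.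

Within the data shown here, no pair of measured compounds differs in one place only, so the effect of this swap cannot be read directly from the data. Among the measured compounds shown here, the only guide is the narrow spread of the measured set: despite their different structures, the values run from compound 3 at 66000 nM to compound 2 at 105000 nM. On that basis, no change beyond the scatter is expected in this assay. The expected move is small, with the estimate being a 1.1-fold higher number from compound 3 to compound 4 (0.04 log units; within the scatter). For compound 4 the estimated value is 72000 nM, with an expected range of 35000 nM to 140000 nM.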

Compound 4, half-maximal inhibitory concentration: 81000 nM
Beside the measured number, compound 4's estimate is 1.1-fold (0.05 log units) below it; measured number inside the range.
By their numbers in this assay, from the lowest: compounds 3, 1, 4 and 2 (each within the scatter of the next).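

In this assay, among these compounds, the exchange of 4-ethylphenyl for 3-methoxyphenyl on a nitrogen on an aromatic ring gives a 1.2-fold higher number from compound 3 to compound 4 (0.09 log units; within the scatter), the first reading from a pair that differs in one place only. With the core of compound 3 held constant, this position accepts the change without a shift beyond the scatter, so the earlier narrow spread across differing structures now has a direct one-place comparison alongside it. The entering group carries a hydrogen-bond acceptor and the leaving group carries none, yet the two compounds cannot be separated in this read-out, and no supporting data explain that outcome.

This single step changes both the identity of the substituent and its numbered place on the ring, so the contribution of each remains unresolved. The compounds shown also leave open whether an amine or a carboxylic acid on this aryl group would move the number beyond the scatter, or whether the level readings would persist with such a group in place.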